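A few compounds are considered here, and "the series" means these few. Any claim that something is new, unique, unknown or untested is made for them only; others in the source may bear on it.

Measured compounds:
compound 1 `COc1ccc2c(O[C@H]3C[C@H]4C(=O)N(C)CCCC/C=C/[C@@H]5C[C@@]5(C(=O)NS(=O)(=O)C5(C)CC5)NC(=O)N4C3)cc(-c3cc(C(C)C)on3)nc2c1Cl`, 75000 nM
compound 2 `COc1ccc2c(O[C@H]3C[C@H]4C(=O)N(C)CCCC/C=C/[C@@H]5C[C@@]5(C(=O)NS(=O)(=O)C5(C)CC5)NC(=O)N4C3)cc(C#N)nc2c1C`, 55800 nM

In an ADME assay on Huh-7 cells (Homo sapiens) for cytotoxicity, read by colorimetric assay (on this read-out lower numbers stand for higher toxicity in this test and higher numbers for lower toxicity in this test), compound 2 gives 55800 nM, and compound 1 gives 75000 nM; the two numbers sit within the scatter of each other, so no order between them is read. Compound 3 `C#Cc1csc(-c2cc(O[C@H]3C[C@H]4C(=O)N(C)CCCC/C=C/[C@@H]5C[C@@]5(C(=O)NS(=O)(=O)C5(C)CC5)NC(=O)N4C3)c3ccc(OC)c(C)c3n2)n1` carries 4-ethynyl-1,3-thiazol-2-yl in place of cyano on an aromatic carbon. Among the measured compounds shown here, no step of this kind has been measured in this assay; on the two numbers in hand, the step from compound 2 to compound 3 is expected to stay small, at most a modest move toward lower numbers, a 1.4-fold lower number from compound 2 to compound 3 (0.14 log units; within the scatter). Compound 3 is therefore estimated at 40000 nM in this assay, with a range from 15000 nM to 100000 nM.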

Compound 3, half-maximal cytotoxic concentration: 75000 nM
Estimate against measurement, compound 3: 1.9-fold (0.27 log units) below, within the range that was stated.
By their numbers in this assay, from the lowest: compounds 2, 1 and 3 (each within the scatter of the next).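

In this assay the change to 4-ethynyl-1,3-thiazol-2-yl in place of cyano, next to the ring nitrogen, gives a 1.3-fold higher number from compound 2 to compound 3 (0.13 log units; within the scatter) and so stays within the scatter. At this position, then, a larger group carrying a five-membered aromatic ring leaves this read-out without a step that can be read. No measurement in hand gives a cause for this result.

Still open, going by these compounds, is whether an amine or a carboxylic acid here would also stay within the scatter. On these data alone, it is also open whether the ethynyl matters, which a plain 1,3-thiazol-2-yl would test.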